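This account rests on a few compounds, and the source may have more. Where it says the series, first, only, none or still open, it means among the compounds named here.

Measured so far in a functional assay on the whole organism (strain albino) for inhibition, with Rattus norvegicus as the target, read by paw edema, with stated times of 30 min and 2 h, at a dose of 50 mg/kg by the oral route; a higher number here means more inhibition at the dose given (going by the name of the read-out), a lower number less inhibition:
compound 1 `O=C(O)CCC(=O)/C=C/c1cn(-c2ccccc2)nc1-c1ccc(Cl)cc1` — 10.9%
compound 2 `NC(=O)c1ccccc1NC(=O)c1cn(-c2ccccc2)nc1-c1ccccc1` — 13.5%
compound 3 `CC(=O)Nc1ccc(OC(=O)c2cn(-c3ccccc3)nc2-c2ccc(Cl)cc2)cc1` — 15.6%

The three values sit within a narrow band, and every gap among them lies within the scatter. Compound 3 gives the uppermost number of the three, yet nothing beyond the scatter separates it from compound 2 or from compound 1, so no ordering can be read from these figures.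

Compound 4 `CC(=O)Nc1ccc(OC(=O)c2cn(-c3ccccc3)nc2-c2ccc(C)cc2)cc1` differs from compound 3 in one place: methyl in place of chloro on an aromatic carbon. Going by the values given here, no step between measured compounds is available for this change, so the size of the step is expected from the narrow spread of the series alone. A step of no more than the scatter is expected in this assay, with no clear direction.

For compound 4 the expected value in this assay is 14%, within 5% to 24%, which is an estimated step of a number 1.6 percentage points lower from compound 3 to compound 4 (within the scatter).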

Compound 4, a percentage reported as inhibition, in the whole organism at one dose (the size of the read-out at that dose, not a potency): 4.17%
For compound 4 the middle estimate is 9.8 percentage points above the measured one, outside the stated range (below it).
By their numbers in this assay, from the lowest: compounds 4, 1, 2 and 3 (each within the scatter of the next, the first and the last beyond it).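

In this assay, going by these compounds alone, the change from 4-chlorophenyl to 4-methylphenyl gives a number 11.4 percentage points lower from compound 3 to compound 4 (beyond the scatter), the first step that can be read as a real difference. This position on the aromatic ring therefore affects inhibition, and of these two groups chloro gives the higher number. Nothing available explains the difference.

From the compounds shown here alone, it remains open whether a fluoro or methoxy group at this position would stay with chloro or fall with methyl. Going by these compounds, whether the same change has a similar effect on other parts of the series also remains open.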